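The source may hold more compounds than are shown below. What is called first, only, known or untested is meant among the compounds shown, and "the series" means these compounds.

Three compounds have been measured so far:
compound 1 `O=C(O)c1ccc2noc(-c3ccc(-c4cccnc4)cc3)c2c1`, 610 nM
compound 2 `O=C(O)c1ccc2noc(-c3ccc(-c4ccncc4)cc3)c2c1`, 670 nM
compound 3 `O=C(O)c1ccc2noc(-c3ccc(Oc4ccccc4)cc3)c2c1`, 550 nM

All three were read in an assay for inhibition of inositol hexakisphosphate kinase 3 (Homo sapiens), read by colorimetric assay, coupled enzyme assay and malachite green, with a stated time of 120 min, in the presence of a further agent that is not named here; a lower number here means a stronger inhibitor, a higher number a weaker inhibitor. Compound 3 stands level with the other two: the step of a 1.1-fold lower number from compound 1 to compound 3 (0.04 log units; within the scatter) and the step of a 1.2-fold lower number from compound 2 to compound 3 (0.09 log units; within the scatter) both sit within the scatter of repeated measurements, so these three numbers cannot be told apart, and no one of them can be called stronger or weaker than another.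

Compound 4 `O=C(O)c1ccc2noc(-c3ccc(Oc4ccccn4)cc3)c2c1` has not yet been measured. It differs from compound 3 in one place: pyridin-2-yl in place of phenyl on an oxygen on an aromatic ring. For the measured compounds named here, none of the measured steps makes exactly this swap. The nearest are the step of a 1.1-fold lower number from compound 1 to compound 3 (0.04 log units; within the scatter) and the step of a 1.2-fold lower number from compound 2 to compound 3 (0.09 log units; within the scatter), each exchanging a pyridinyl ring for a phenoxy group, and the step of a 1.1-fold higher number from compound 1 to compound 2 (0.04 log units; within the scatter), which moves the ring nitrogen of a pyridinyl ring; all three stayed within the scatter. On that record, no step beyond the scatter is expected in this assay in either direction. Compound 4 is therefore estimated at 550 nM, with a likely range from 250 nM to 1200 nM. The expected step of no change at the digits printed from compound 3 to compound 4 (within the scatter) is essentially flat.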

Compound 4, half-maximal inhibitory concentration: 2060 nM
Beside the measured number, compound 4's estimate is 3.7-fold (0.57 log units) below it, and the stated range ends below it.
By their numbers in this assay, from the lowest: compounds 3, 1 and 2 (each within the scatter of the next); then compound 4.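

In this assay, for the compounds shown here, the change from phenyl to pyridin-2-yl on the oxygen gives a 3.7-fold higher number from compound 3 to compound 4 (0.57 log units; beyond the scatter) and is the first single change in this set to go beyond the scatter, so this position does respond to what is attached there, even though the swap keeps the count of heavy atoms and adds only one ring nitrogen. Compound 4 also separates from the two directly attached pyridinyl compounds, with a 3.1-fold higher number from compound 2 to compound 4 (0.49 log units; beyond the scatter) and with a 3.4-fold higher number from compound 1 to compound 4 (0.53 log units; beyond the scatter) in the same direction, so a ring nitrogen in the outer ring is not neutral in every setting: compound 1 and compound 2 stay level with compound 3, while compound 4 does not. Nothing available explains why this one swap raises the number.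

The compounds shown leave open whether the rise belongs to this particular ring or to any nitrogen in a ring on the oxygen, a question that (pyridin-3-yl)oxy and (pyridin-4-yl)oxy groups would address. They also leave open how a phenoxy ring carrying a methoxy group or a chlorine would read in this assay.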